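Chloro on the pendant phenyl across two cores

A few compounds are considered here, and "the series" means these few. Any claim that something is new, unique, unknown or untested is made for them only; others in the source may bear on it.

Compound 1 `Nc1cccc(-c2cn3nc(Cc4ccccc4)sc3n2)c1` and compound 2 `Nc1cccc(-c2cn3nc(Cc4ccc(Cl)cc4)sc3n2)c1` share one core and differ only in that compound 2 carries chloro in place of hydrogen on an aromatic carbon. In a functional assay on L1210 cells (Mus musculus) for inhibition, read by cell counting, with a stated time of 2 days (a lower number here means a stronger inhibitor, a higher number a weaker inhibitor), compound 1 gives 7400 nM, and in this assay compound 2 gives 16000 nM. The step of a 2.2-fold higher number from compound 1 to compound 2 (0.33 log units; beyond the scatter) thus runs toward the weaker side, and by a modest amount.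

Compound 3 `C=C(Br)C(=O)Nc1cccc(-c2cn3c(-c4ccccc4)csc3n2)c1` sits on a different core, and the difference between the two cores is not broken down here. In this assay compound 3 gives 1300 nM, the lowest number of the three measured compounds, with compound 1 nearest and compound 2 furthest from it.

Compound 4 `C=C(Br)C(=O)Nc1cccc(-c2cn3c(-c4ccc(Cl)cc4)csc3n2)c1` is not yet measured. For the measured compounds named here, it differs from compound 3 by chloro in place of hydrogen on an aromatic carbon, the same change as the one from compound 1 to compound 2, set on the same place, para to a large group, with the phenyl read as 4-chlorophenyl one bond further out.

The expectation for compound 4 rests on a single precedent, the step of a 2.2-fold higher number from compound 1 to compound 2 (0.33 log units; beyond the scatter), so the range is kept wide. The step of a 2.2-fold higher number from compound 3 to compound 4 (0.33 log units; beyond the scatter) is the expected size of the change for compound 4 in this assay. Going by the values given here, compound 4 is expected to give about 2800 nM in this assay, within 1300 nM to 6500 nM, because the one measured instance of this change gave a 2.2-fold higher number from compound 1 to compound 2 (0.33 log units; beyond the scatter).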

Compound 4, half-maximal inhibitory concentration: 1900 nM
Beside the measured number, compound 4's estimate is 1.5-fold (0.17 log units) above it, within the range that was stated.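

In this assay, chloro in place of hydrogen on the core of compound 3 gives a 1.5-fold higher number from compound 3 to compound 4 (0.16 log units; within the scatter), so compound 3 and compound 4 cannot be told apart in this read-out. Set beside the earlier instance, the change shows no detectable difference in size between the two cores, and the first-core step is therefore a usable guide for the second within this small set: the same change on two cores in this assay, a 2.2-fold higher number (0.33 log units; beyond the scatter) from compound 1 to compound 2 and a 1.5-fold higher number (0.16 log units; within the scatter) from compound 3 to compound 4, 1.5-fold (0.17 log units) apart, within the scatter of two such steps This does not establish that the change has the same size on both cores, since it rests on only two pairs, one step lying beyond the scatter and the other within it, and the pairs differ not only in the core but also in the group on the other phenyl ring, a free amine in compound 1 and compound 2 and a bromo-substituted acrylamide in compound 3 and compound 4.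

The compounds shown leave open whether fluoro, methoxy or a carboxylic acid in the same place would carry across the two cores in the same way, and what chloro does elsewhere on the phenyl ring. They also leave open how the free amine and the bromo-substituted acrylamide compare on one and the same core.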